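This account rests on a few compounds, and the source may have more. Where it says the series, first, only, none or still open, it means among the compounds named here.

Compound 1 `CN(C(=O)NC(=O)c1cccc(C(F)(F)F)c1)c1nc(C(F)(F)F)c(C(=O)N/N=C/c2cccc(C(F)(F)F)c2)s1` gives 3.7 ug/mL in a functional assay on MCF7 cells (Homo sapiens) for inhibition, read by MTT assay, with a stated time of 72 h; on this read-out lower numbers stand for stronger inhibition and higher numbers for weaker inhibition.
Compound 2 `CN(C(=O)NC(=O)c1cccc(C(F)(F)F)c1)c1nc(C(F)(F)F)c(C(=O)N/N=C/c2ccccc2C(F)(F)F)s1` gives 7.69 ug/mL in this assay.
Compound 3 `Cc1nc(N(C)C(=O)NC(=O)c2c(F)cccc2F)sc1C(=O)N/N=C/c1cc(C(F)(F)F)cc(C(F)(F)F)c1` gives 11.6 ug/mL in this assay.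

Among the compounds with values here, compound 1 stands lowest of the three numbers in this assay; compound 2 is nearest, and the only single-place step measured so far is a 2.1-fold higher number from compound 1 to compound 2 (0.32 log units; beyond the scatter), a change on the carbon with a double bond to nitrogen. Within the data shown here, compound 3 differs from compound 1 at several places at once and yields no single step.

Compound 4 `CN(C(=O)NC(=O)c1ccc(Cl)cc1Cl)c1nc(C(F)(F)F)c(C(=O)N/N=C/c2cccc(C(F)(F)F)c2)s1` differs from compound 1 in one place: 2,4-dichlorophenyl in place of 3-(trifluoromethyl)phenyl on a carbonyl carbon. Among the measured compounds shown here, no measured step touches the ring on the carbonyl carbon, so the data give no direction for this change. It is therefore expected that compound 4 stays close to compound 1, with a 1.2-fold higher number from compound 1 to compound 4 (0.09 log units; within the scatter) within the scatter. The estimate for compound 4 in this assay is 4.5 ug/mL, expected between 2 ug/mL and 10 ug/mL.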

Compound 4, half-maximal inhibitory concentration: 10.7 ug/mL
For compound 4 the middle estimate is 2.4-fold (0.38 log units) below the measured one, outside the stated range (above it).
By their numbers in this assay, from the lowest: compound 1; then compounds 2, 4 and 3 (each within the scatter of the next).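

The ring on the carbonyl carbon does affect the read-out: in this assay, 2,4-dichlorophenyl in place of 3-(trifluoromethyl)phenyl gives a 2.9-fold higher number from compound 1 to compound 4 (0.46 log units; beyond the scatter). This first measured step at this position runs the same way as the change on the carbon with a double bond to nitrogen, a 2.1-fold higher number from compound 1 to compound 2 (0.32 log units; beyond the scatter), so compound 1 holds the lower number in both single-place pairs. Nothing on hand gives a reason for the new step.

Whether either chlorine alone accounts for the step remains open. So does how a carboxylic acid or an amine on this ring would read.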